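Chloro to bromo on two related cores

The source may hold more compounds than are shown below. What is called first, only, known or untested is meant among the compounds shown, and "the series" means these compounds.

Compound 1 `O=[N+]([O-])c1cc(-c2nnn(Cc3cccc(Cl)c3)n2)cc([N+](=O)[O-])c1` and compound 2 `O=[N+]([O-])c1cc(-c2nnn(Cc3cccc(Br)c3)n2)cc([N+](=O)[O-])c1` share one core and differ only in a single halogen. In an ADME assay on CHO-K1 cells (Cricetulus griseus) for cytotoxicity, read by MTT assay, with a stated time of 24 h (on this read-out higher numbers stand for weaker inhibition and lower numbers for stronger inhibition), compound 1 gives 27000 nM, and compound 2 gives 29000 nM. The change between them is bromo in place of chloro on an aromatic carbon, and it made a 1.1-fold higher number from compound 1 to compound 2 (0.03 log units; within the scatter). Compound 3 `O=[N+]([O-])c1cc(-c2nnn(CSc3nnnn3-c3ccc(Cl)cc3)n2)cc([N+](=O)[O-])c1` is built on another core; how the two cores differ is not broken down here. In this assay compound 3 gives 14000 nM, a number within the scatter of compound 1 and beyond the scatter of compound 2. Compound 4 `O=[N+]([O-])c1cc(-c2nnn(CSc3nnnn3-c3ccc(Br)cc3)n2)cc([N+](=O)[O-])c1` has not yet been measured. It differs from compound 3 by bromo in place of chloro on an aromatic carbon. Going by the values given here, this is the same kind of change as the one from compound 1 to compound 2, but not the same: in compound 3 the chloro sits para to a large group, whereas in compound 1 it sits meta to a large group. Because the earlier change gave a 1.1-fold higher number from compound 1 to compound 2 (0.03 log units; within the scatter), the expected step is a 1.1-fold higher number from compound 3 to compound 4 (0.03 log units; within the scatter). Compound 4 is therefore estimated at 15000 nM, with a likely range from 8000 nM to 30000 nM.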

Compound 4, half-maximal inhibitory concentration: 29000 nM
Estimate against measurement, compound 4: 1.9-fold (0.29 log units) below, and the stated range covers the measured number.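

On the core of compound 3, putting bromo in place of chloro gave a 2.1-fold higher number from compound 3 to compound 4 (0.32 log units; beyond the scatter) in this assay. Set beside the earlier case, the two steps point the same way and cannot be told apart in size, so this change carries over from one core to the other as far as these two pairs can show: the same change on two cores in this assay, a 1.1-fold higher number (0.03 log units; within the scatter) from compound 1 to compound 2 and a 2.1-fold higher number (0.32 log units; beyond the scatter) from compound 3 to compound 4, 1.9-fold (0.29 log units) apart, within the scatter of two such steps. Going by these compounds alone, this does not show that the step has one fixed size on every core: only two pairs are available, only the second step lies beyond the scatter, and the data give no reason for that difference.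

The compounds shown carry only chloro and bromo at these places on their benzene rings, and each core has a single such pair. On these data alone, how a fluoro, a methoxy group or an amine at the same place would read in this assay, and whether either core would respond to it in the same way, remains open.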